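Trading 4-methylphenyl for 4-methylbenzyl on the amide-type nitrogen

The compounds below may be only part of what the source reports. "The series", "measured", "known", "first", "only" and "open" are said of these compounds alone.

In a functional assay on HeLa cells (Homo sapiens) for inhibition, read by MTT assay, with a stated time of 72 h (a higher number here means a weaker inhibitor, a lower number a stronger inhibitor), compound 1 (`C=C(Br)C(=O)Nc1cccc(/C=C/C(=O)Nc2ccccc2)c1`) gives 7300 nM and compound 2 (`C=C(Br)C(=O)Nc1cccc(/C=C/C(=O)Nc2ccc(Cl)cc2)c1`) gives 2800 nM while compound 3 (`C=C(Br)C(=O)Nc1cccc(/C=C/C(=O)Nc2ccc(C)cc2)c1`) gives 1500 nM on the same read-out. Compound 3 is not separated from compound 2 given a 1.9-fold lower number from compound 2 to compound 3 (0.27 log units; within the scatter) here, yet it stands clear of compound 1 with a 4.9-fold lower number from compound 1 to compound 3 (0.69 log units; beyond the scatter) as the gap. Compound 4 (`C=C(Br)C(=O)Nc1cccc(/C=C/C(=O)NCc2ccc(C)cc2)c1`) carries 4-methylbenzyl in place of 4-methylphenyl on an amide-type nitrogen. Within the data shown here, no measured step makes this change, so the nearest guide is the modest 2.6-fold lower number from compound 1 to compound 2 (0.42 log units; beyond the scatter) alongside the modest step to compound 3. A modest rise in this assay is therefore expected, though the data fix no direction. The expected change is a 1.7-fold higher number from compound 3 to compound 4 (0.22 log units; within the scatter) as estimated here. For compound 4 the estimate is 2500 nM with an expected range from 800 nM to 7000 nM in this read-out.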

Compound 4, half-maximal inhibitory concentration: 1700 nM
The estimate for compound 4 lay 1.5-fold (0.17 log units) above the measured number; the measured number falls inside the stated range.
By their numbers in this assay, from the lowest: compounds 3, 4 and 2 (each within the scatter of the next); then compound 1.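

In this assay, 4-methylbenzyl on the amide-type nitrogen does not separate from 4-methylphenyl, with a 1.1-fold higher number from compound 3 to compound 4 (0.05 log units; within the scatter), so in this one pair the position accepts the change without a readable shift. The benzyl compound is likewise not separated from the 4-chlorophenyl compound, with a 1.6-fold lower number from compound 2 to compound 4 (0.22 log units; within the scatter), yet it stands clear of the plain phenyl compound, with a 4.3-fold lower number from compound 1 to compound 4 (0.63 log units; beyond the scatter). Nothing available explains this result. Still open, going by these compounds, is whether a longer chain such as 4-methylphenethyl on this nitrogen would behave the same way, and whether plain benzyl or 4-chlorobenzyl would match 4-methylbenzyl.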